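The source may hold more compounds than are shown below. What is called first, only, known or untested is meant among the compounds shown, and "the series" means these compounds.

In an ADME assay on a cell-free system (serum, Homo sapiens) for metabolic stability, read by HPLC, tested at 2 mM (on this read-out higher numbers stand for a longer-lived compound and lower numbers for a shorter-lived compound), compound 1 `CCCCCCCCCc1ccc(OP(=O)(O)OC[C@H]2O[C@@H](n3cc(F)c(=O)[nH]c3=O)C[C@@H]2OC(=O)c2ccccc2)cc1` gives > 120 h, which is a limit of the assay and not a number. For the measured compounds named here, compound 2 `C[n+]1cccc(OP(=O)([O-])OC[C@H]2O[C@@H](n3cc(F)c(=O)[nH]c3=O)C[C@@H]2OC(=O)c2ccccc2)c1` gives 37.3 h, so it is the only compound here with an exact half-life and serves as the firm starting point. Compound 3 `CCCCCCCCCC[n+]1cccc(OP(=O)([O-])OC[C@H]2O[C@@H](n3cc(F)c(=O)[nH]c3=O)C[C@@H]2OC(=O)c2ccccc2)c1` keeps the frame of compound 2 and changes it in one place: nonyl in place of hydrogen on a saturated chain carbon bound to an aromatic nitrogen. This is nonyl in place of hydrogen on a saturated chain carbon bound to an aromatic nitrogen, so methyl becomes decyl. Going by the values given here, no measured pair shows what such a change does, and the only further guide is compound 1, which marks (the limit of > 120 h in this assay, at which 1 of the 2 values shown sits). On that basis, the expected change, a 2.1-fold higher number from compound 2 to compound 3 (0.33 log units; beyond the scatter), is a lengthening of half-life somewhat beyond the usual scatter. For compound 3 the estimated half-life is 80 h, with an expected range of 30 h to 200 h.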

Compound 3, half-life: 8.3 h
Beside the measured number, compound 3's estimate is 9.6-fold (0.98 log units) above it; the whole stated range lies above it.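

At the saturated chain carbon bound to an aromatic nitrogen, nonyl in place of hydrogen, which turns methyl into decyl, gives in this assay a 4.5-fold lower number from compound 2 to compound 3 (0.65 log units; beyond the scatter) as its result. For the compounds shown here, this is the first single-place change that can be read here, and it shows that this position is not indifferent to the chain it carries: the half-life moves down, and by more than the usual scatter. Nothing measured here gives a reason for that drop.

On these data alone, with only methyl and decyl at this position, it stays open whether the half-life falls steadily with length or drops abruptly at some intermediate chain, such as butyl or hexyl. As far as these compounds go, it is also open how a chain ending in an amine or a carboxylic acid would behave in this assay compared with plain decyl.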